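The compounds below may be only part of what the source reports. "The series", "measured", "known", "first", "only" and "open" are said of these compounds alone.

Measured in an assay on CHO cells for displacement of a labelled ligand from adenosine receptor A1 (Homo sapiens), read by scintillation counting, with a stated time of 1 h, tested at 1 uM; a lower number here means less inhibition, a higher number more inhibition at the concentration tested (going by the name of the read-out):
compound 1 `Nc1ncc(-c2ccccc2)c(-c2ccccc2)n1` gives 32%.
compound 2 `COc1ccc(-c2cnc(N)nc2-c2ccccc2)cc1OC` gives a value that is a limit of the assay, > 80%.
compound 3 `CCCC(=O)Nc1ncc(-c2cccc(Cl)c2)c(-c2ccccc2)n1` gives a value that is a limit of the assay, > 80%.

Compound 3 stands at the limit of > 80% in this assay, at which 2 of the 3 values shown sit, so its place among the three is known only as a limit and not as a number. The unmeasured compound 4 `Clc1cccc(-c2cnc(NC3CCCCC3)nc2-c2ccccc2)c1` differs from compound 3 by cyclohexyl in place of propylcarbonyl on a nitrogen on an aromatic ring. No step between measured compounds is shown, so the size of this change is open. Compound 4 is expected to give about 75%, within 50% to 95%. The step of a number at least 5 percentage points lower from compound 3 to compound 4 (that floor lies within the scatter) is thus expected to be small, with a fair chance that the assay again reports only its limit.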

Compound 4, a percentage reported as inhibition, at one concentration (the size of the read-out at that concentration, not a potency): 58%
The estimate for compound 4 lay 17 percentage points above the measured number, and the stated range covers the measured number.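

In this assay, cyclohexyl in place of propylcarbonyl on a nitrogen on an aromatic ring gives a number at least 22 percentage points lower from compound 3 to compound 4 (beyond the scatter). For the compounds shown here, this is the first comparison that differs in one place, and it shows that the read-out responds to the group on this nitrogen. Compound 3 gives > 80%, which is a limit of the assay, so the full size of the step stays unknown: the limit of > 80% in this assay, at which 2 of the 4 values shown sit.

Going by these compounds, whether the step follows the loss of the carbonyl or the arrival of the ring remains open. A straight-chain alkylamino group or a cyclohexylcarbonyl amide on this nitrogen, with the rest of compound 3 kept, would separate the two.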